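Aryl variation on the shared core: compound 4

This account rests on a few compounds, and the source may have more. Where it says the series, first, only, none or still open, it means among the compounds named here.

Measured so far in a functional assay on SN12C cells (Homo sapiens) for inhibition, read by sulforhodamine B assay, with a stated time of 48 h, tested at 10 uM; a higher number here means more inhibition at the concentration tested (going by the name of the read-out), a lower number less inhibition:
Compound 1 `c1ccc2c(-c3cn4ccnc4c(-c4ccc5ncn(C6CCCCC6)c5c4)n3)cccc2c1` gives 11.7%
Compound 2 `Clc1ccc(-c2cn3ccnc3c(-c3ccc4ncn(C5CCCCC5)c4c3)n2)cc1` gives 13.5%
Compound 3 `Brc1ccc(-c2cn3ccnc3c(-c3ccc4ncn(C5CCCCC5)c4c3)n2)cc1` gives 18.4%

Compound 3 holds the largest of the three numbers, though the steps of a number 4.9 percentage points higher from compound 2 to compound 3 (within the scatter) and a number 6.7 percentage points higher from compound 1 to compound 3 (within the scatter) both lie within the scatter, as does a number 1.8 percentage points higher from compound 1 to compound 2 (within the scatter). Within the data shown here, the three measured compounds therefore read as one flat group: changing the aryl group on the shared core of compound 1 between naphthalen-1-yl, 4-chlorophenyl and 4-bromophenyl has produced no step that can be told apart from repeat noise.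

Compound 4 `COc1ccccc1-c1cn2ccnc2c(-c2ccc3ncn(C4CCCCC4)c3c2)n1` is not yet measured. 2-methoxyphenyl in place of 4-bromophenyl on an aromatic carbon

Among the measured compounds shown here, no measured step introduces a hydrogen-bond acceptor at this aryl group, so none bears directly on the methoxy change; the nearest analogues are the aryl swaps above, all within the scatter. Compound 4 is therefore expected to sit with the group, and the step of a number 4.4 percentage points lower from compound 3 to compound 4 (within the scatter) is estimated to stay within the scatter. Compound 4 is estimated at 14%, with a range from 4% to 26%.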

Compound 4, a percentage reported as inhibition, at one concentration (the size of the read-out at that concentration, not a potency): 7.73%
Compound 4: the middle estimate sits 6.3 percentage points above what was measured; low and high end bracket the measured number.
By their numbers in this assay, from the lowest: compounds 4, 1, 2 and 3 (each within the scatter of the next, the first and the last beyond it).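

In this assay, among these compounds, the step of a number 10.7 percentage points lower from compound 3 to compound 4 (beyond the scatter) is the first at this aryl position to lie beyond the scatter, so the position is not wholly flat. The steps of a number 5.8 percentage points lower from compound 2 to compound 4 (within the scatter) and a number 4 percentage points lower from compound 1 to compound 4 (within the scatter) both stay within the scatter, so the separation holds only against 4-bromophenyl, and compound 4 does not form a group apart from compound 1 and compound 2. No measurement available here explains the step from 4-bromophenyl to 2-methoxyphenyl.

From the compounds shown here alone, it remains open whether the lower number of compound 4 against compound 3 follows the methoxy group itself or its place on the phenyl ring, a question that a 4-methoxyphenyl group on the shared core would address. Also open, going by these compounds, is how this assay would read for a phenyl group carrying an amine or a carboxylic acid.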